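Cyclopentyloxy to cyclohexyloxy in a growth inhibition series

The compounds below may be only part of what the source reports. "The series", "measured", "known", "first", "only" and "open" are said of these compounds alone.

In a functional assay on HT-29 cells (Homo sapiens) for inhibition, read by sulforhodamine B assay, with a stated time of 48 h (a higher number here means a weaker inhibitor of growth, a lower number a stronger inhibitor of growth), compound 3 (`O=C(CCl)NC(=O)Nc1ccc(OC2CCCC2)cc1`) gives 3100 nM as its number. In this assay compound 2 (`O=C(CCl)NC(=O)Nc1ccc(C2CCCCC2)cc1`) gives 2300 nM and lies within the scatter of compound 3. In this assay compound 1 (`c1cc(OC2CCCCC2)ccc1NC1=NCCO1`), built on a different core, gives 12600 nM as a number beyond the scatter from that of compound 3.

Compound 4 (`O=C(CCl)NC(=O)Nc1ccc(OC2CCCCC2)cc1`) departs from compound 3 by one change: cyclohexyl in place of cyclopentyl on an oxygen on an aromatic ring with cyclohexyl in place of cyclopentyl on an oxygen on an aromatic ring. For the measured compounds named here, one measured step bears on this change: a 1.3-fold higher number from compound 2 to compound 3 (0.13 log units; within the scatter) with cyclopentyloxy in place of cyclohexyl on an aromatic carbon. Going by the values given here, that step does not test the ring alone, and no measured step links compound 1 to the others. Even so, its small size leads to the expectation of no shift beyond the scatter in this assay for this change. The expected outcome is a 1.1-fold lower number from compound 3 to compound 4 (0.06 log units; within the scatter) and no more. For compound 4 the estimated value is 2700 nM with an expected range from 1300 nM to 5500 nM in this measurement.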

Compound 4, concentration for 50% growth inhibition: 3100 nM
For compound 4 the middle estimate is 1.1-fold (0.06 log units) below the measured one; measured number inside the range.
By their numbers in this assay, from the lowest: compounds 2, 3 and 4 (each within the scatter of the next); then compound 1.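

In this assay, for the compounds shown here, cyclohexyl in place of cyclopentyl on an oxygen on an aromatic ring gives no change at the digits printed from compound 3 to compound 4 (within the scatter), which is the first direct reading of this ring change, and it stays within the scatter. Cyclohexyloxy in place of cyclohexyl on an aromatic carbon gives a 1.3-fold higher number from compound 2 to compound 4 (0.13 log units; within the scatter), also within the scatter, whereas changing the group on a nitrogen on an aromatic ring gives a 4.1-fold lower number from compound 1 to compound 4 (0.61 log units; beyond the scatter), a modest step beyond the scatter. Nothing shown here accounts for these readings.

The compounds shown cover only two saturated carbon rings on this oxygen, so they leave open whether an open hexyl chain or a ring carrying an amine would give a step beyond the scatter. They also leave open whether any such result would hold outside this one cell line.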